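Ring nitrogen substituent swap: isopropyl to cyclopentyl

A few compounds are considered here, and "the series" means these few. Any claim that something is new, unique, unknown or untested is made for them only; others in the source may bear on it.

Measured compounds:
compound 1 `CC(C)n1cnc2c(Nc3ccccc3)nc(NCOCc3ccc(C(=O)Nc4ccccc4N)cc3)nc21` — 50.2%
compound 2 `CC(C)n1cnc2c(NCc3ccc(C(=O)Nc4ccccc4N)cc3)nc(Cl)nc21` — 74.4%
compound 3 `Nc1ccccc1NC(=O)c1ccc(CNc2nc(Cl)nc3c2ncn3C2CCCC2)cc1` — 74.9%

In a functional assay on HepG2 cells (Homo sapiens) for antiproliferative activity, read by CCK-8 assay, with a stated time of 72 h, tested at 8 uM (a lower number here means a weaker effect, a higher number a stronger effect of the compound at the concentration tested), compound 1 stands lowest of the three numbers, with compound 2 and compound 3 both beyond the scatter above it. The cores of compound 1 and compound 2 differ in more than one place; that difference between the two cores is not broken down here.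

Within the pair that shares a core, the step is a number 0.5 percentage points higher from compound 2 to compound 3 (within the scatter). The change is cyclopentyl in place of isopropyl on an aromatic nitrogen.

Compound 4 `Nc1ccccc1NC(=O)c1ccc(COCNc2nc(Nc3ccccc3)c3ncn(C4CCCC4)c3n2)cc1` is not yet measured. It arises from compound 1 by cyclopentyl in place of isopropyl on an aromatic nitrogen, the same change as that from compound 2 to compound 3, with the place described in identical words. Within the data shown here, the only guide is the one measured step, which lies within the scatter.

For compound 4 the expected step is therefore a number 0.8 percentage points higher from compound 1 to compound 4 (within the scatter), resting on compound 2 to compound 3 because a number 0.5 percentage points higher from compound 2 to compound 3 (within the scatter) is within the scatter. Among the measured compounds shown here, the estimate for compound 4 in this assay is 51%, expected to fall between 40% and 63%; the single precedent gives no reason to expect a larger move.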

Compound 4, a percentage reported as inhibition, at one concentration (the size of the read-out at that concentration, not a potency): 66.9%
The estimate for compound 4 lay 15.9 percentage points below the measured number; the measured number lies above the stated range.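

In this assay, the step for cyclopentyl in place of isopropyl on an aromatic nitrogen is a number 16.7 percentage points higher from compound 1 to compound 4 (beyond the scatter). The change does not carry over at one size from one core to the other: the same change on two cores in this assay, a number 0.5 percentage points higher (within the scatter) from compound 2 to compound 3 and a number 16.7 percentage points higher (beyond the scatter) from compound 1 to compound 4, 16.2 percentage points apart, beyond the scatter of two such steps. So the step read on the core of compound 2 is no reliable guide to its size on the core of compound 1, but with only one pair on each core this gives no rule for other cores, and it does not show which of the several differences between the two cores goes with the larger step.

Going by these compounds, it remains open which single part of the core of compound 1 is tied to the larger step, which would take compounds differing from it in one place at a time. Also open, on these data alone, is whether cyclohexyl or a longer chain on the same aromatic nitrogen would follow cyclopentyl on either core.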